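A few compounds are considered here, and "the series" means these few. Any claim that something is new, unique, unknown or untested is made for them only; others in the source may bear on it.

Measured in a functional assay on HCT-116 cells (Homo sapiens) for antiproliferative activity, read by CellTiter-Glo, with a stated time of 10 days; a higher number here means a weaker inhibitor, a lower number a stronger inhibitor:
- compound 1 `Cn1ncc(-c2cc(Cl)c3c(=O)[nH]nc(CN)c3c2)c1-c1sc2ccccc2c1C#N`: 734 nM
- compound 2 `Cn1ncc(-c2cc(C(F)F)c3c(=O)[nH]nc(CN)c3c2)c1-c1sc2ccccc2c1C#N`: 2030 nM
- compound 3 `Cn1ncc(-c2cc(O)c3c(=O)[nH]nc(CN)c3c2)c1-c1sc2ccccc2c1C#N`: 4350 nM

Among these three, compound 3, at 4350 nM, has the highest number and is the weakest inhibitor. Compound 4 `Cc1cc(-c2cnn(C)c2-c2sc3ccccc3c2C#N)cc2c(CN)n[nH]c(=O)c12` has yet to be measured. It differs from compound 3 by methyl in place of hydroxy on an aromatic carbon.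

Among the compounds with values here, no methyl compound has been measured at this carbon, so the expectation rests on the other groups there. Two modest steps show hydroxy giving the higher number: a 5.9-fold higher number from compound 1 to compound 3 (0.77 log units; beyond the scatter) and a 2.1-fold higher number from compound 2 to compound 3 (0.33 log units; beyond the scatter). The remaining step, a 2.8-fold higher number from compound 1 to compound 2 (0.44 log units; beyond the scatter), shows that the groups other than hydroxy also differ from each other. Taking hydroxy away is therefore expected to lower the number by a modest step, of a size similar to those seen. The expected step is a 3.6-fold lower number from compound 3 to compound 4 (0.56 log units; beyond the scatter). For compound 4 the estimated value is 1200 nM, with an expected range of 450 nM to 3200 nM.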

Compound 4, half-maximal inhibitory concentration: 1470 nM
Beside the measured number, compound 4's estimate is 1.2-fold (0.09 log units) below it; low and high end bracket the measured number.
By their numbers in this assay, from the lowest: compounds 1, 4 and 2 (each within the scatter of the next, the first and the last beyond it); then compound 3.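

In this assay methyl in place of hydroxy gives a 3.0-fold lower number from compound 3 to compound 4 (0.47 log units; beyond the scatter) and leaves compound 3 the weakest of the four. Methyl cannot be told apart from the other two groups, with a 1.4-fold lower number from compound 2 to compound 4 (0.14 log units; within the scatter) and a 2.0-fold higher number from compound 1 to compound 4 (0.30 log units; within the scatter) both within the scatter, although chloro and difluoromethyl are separated beyond it. A plain methyl without halogen therefore stays with chloro and difluoromethyl at this carbon, and hydroxy alone stands apart from all three.

The compounds shown leave open whether a larger group here, such as ethyl or methoxy, would stay with these three or move towards hydroxy. They also leave open how an amine, which like hydroxy is attached through a heteroatom, would compare.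

Nothing in the data shown accounts for these differences.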